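Propoxy-linked aryl variants on the shared core

A few compounds are considered here, and "the series" means these few. Any claim that something is new, unique, unknown or untested is made for them only; others in the source may bear on it.

Measured so far:
compound 1 `CC(C)=CCC/C(C)=C/CC1Cc2c(O)cc(=O)n(CCCO)c2CC1(C)C` – 28.7%
compound 2 `COc1ccc(C(=O)NCCCOc2cc(=O)n(CCCO)c3c2CC(C/C=C(\C)CCC=C(C)C)C(C)(C)C3)cc1` – 45.7%

In a functional assay on PANC-1 cells (Homo sapiens) for inhibition, read by MTT assay, with a stated time of 24 h, tested at 10 uM (a higher number here means more inhibition at the concentration tested (going by the name of the read-out), a lower number less inhibition), compound 1 gives 28.7% and compound 2 gives 45.7%. Compound 2 stands highest of the two numbers, and its gap to compound 1 lies beyond the scatter. Compound 3 `CC(C)=CCC/C(C)=C/CC1Cc2c(OCCCOc3ccc(Cl)cc3)cc(=O)n(CCCO)c2CC1(C)C` is not yet measured; it differs from compound 2 by 4-chlorophenoxy in place of ((4-methoxyphenyl)carbonyl)amino on a saturated chain carbon, three bonds along the chain from an oxygen on an aromatic ring. The change keeps the chain on the aromatic oxygen and swaps the terminal aryl group. The step expected is a number 5.7 percentage points lower from compound 2 to compound 3 (within the scatter), a small decrease within the scatter. Compound 3 is estimated at 40%, in the range 25% to 58%.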

Compound 3, a percentage reported as inhibition, at one concentration (the size of the read-out at that concentration, not a potency): 25.2%
Compound 3: the middle estimate sits 14.8 percentage points above what was measured; the range from low to high includes it.
By their numbers in this assay, from the lowest: compounds 3 and 1 (each within the scatter of the next); then compound 2.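

In this assay 4-chlorophenoxy in place of ((4-methoxyphenyl)carbonyl)amino gives a number 20.5 percentage points lower from compound 2 to compound 3 (beyond the scatter), so the group at the chain end counts at this position. 3-(4-chlorophenoxy)propyl in place of hydrogen on the aromatic oxygen gives a number 3.5 percentage points lower from compound 1 to compound 3 (within the scatter), so a chain on that oxygen does not by itself raise the number. No evidence on hand bears on this difference.

From the compounds shown here alone, whether the amide link or the methoxyphenyl ring carries the gap stays open, since the two change together. Going by these compounds, how an amine or a carboxylic acid at the chain end, or a longer chain, would read also stays open.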